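This account rests on a few compounds, and the source may have more. Where it says the series, first, only, none or still open, it means among the compounds named here.

In a functional assay with Homo sapiens as the target (a higher number here means a weaker inhibitor, a lower number a stronger inhibitor), compound 2 `O=C(O)CCC/C=C1\C[C@H]2C[C@@H](O)[C@H](/C=N/OCc3ccccc3)[C@H]2C1` gives 2000 nM and compound 1 `O=C(O)CCC/C=C1\C[C@H]2C[C@@H](O)[C@H](/C=N/OCc3ccc(F)cc3)[C@H]2C1` gives 1500 nM, so the two stand level, with a 1.3-fold higher number from compound 1 to compound 2 (0.12 log units; within the scatter). Compound 3 `O=C(O)CCC/C=C1/C[C@H]2C[C@@H](O)[C@H](/C=N/OCc3ccccc3)[C@H]2C1` reads > 50000 nM, which is a limit of the assay. The step to that limit is an at least 25-fold higher number from compound 2 to compound 3 (1.39 log units; beyond the scatter), and it comes with the fact that compounds 2 and 3 differ only in the configuration as drawn.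

Compound 4 `O=C(O)CCC/C=C1\C[C@H]2C[C@@H](O)[C@H](/C=N/OCc3ccc4ccccc4c3)[C@H]2C1` carries naphthalen-2-yl in place of phenyl on a saturated chain carbon bound to an oxygen. Its double bond is drawn as in compound 2, so the large step to compound 3 does not bear on this change. The closer guide is the change of hydrogen in place of fluoro on an aromatic carbon, a 1.3-fold higher number from compound 1 to compound 2 (0.12 log units; within the scatter), which left this assay within the scatter. Within the data shown here, no measured step enlarges the aromatic group, so the expectation is loose and no shift beyond the scatter is expected in either direction. The expected size is a 1.3-fold lower number from compound 2 to compound 4 (0.12 log units; within the scatter). For compound 4 the estimated value is 1500 nM, with an expected range of 400 nM to 6000 nM.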

Compound 4, half-maximal inhibitory concentration: 1100 nM
Beside the measured number, compound 4's estimate is 1.4-fold (0.13 log units) above it; the measured number falls inside the stated range.
By their numbers in this assay, from the lowest: compounds 4, 1 and 2 (each within the scatter of the next). At a limit, above all of these: compound 3.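

On a saturated chain carbon bound to an oxygen, naphthalen-2-yl, with 10 heavy atoms and 2 six-membered aromatic rings, reads level with phenyl in this assay (a 1.8-fold lower number from compound 2 to compound 4 (0.26 log units; within the scatter)). Among these compounds, it also reads level with 4-fluorophenyl (a 1.4-fold lower number from compound 1 to compound 4 (0.13 log units; within the scatter)), so compounds 1, 2 and 4 stand together, and this place so far takes the larger carbon-only aromatic group with no shift beyond the scatter. Nothing at hand gives a reason for this level reading.

Open, as far as these compounds go, is how this place reads with an amine or a pyridyl group in place of phenyl, or with a longer chain carrying the aromatic ring. Also open, from the compounds shown here alone, is how naphthalen-2-yl reads with the double bond drawn as in compound 3.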